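The source may report more compounds than this note shows. Statements on the series, on what has been measured and on what is new or still open speak of the compounds shown alone.

Values in a functional assay on thoracic aorta (Rattus norvegicus, strain Wistar), with a stated time of 15 min; on this read-out lower numbers stand for an effect already at smaller amounts and higher numbers for an effect only at larger amounts of compound:

compound 1 (`CCOc1ccc(F)cc1C(C)NC(=O)NS(=O)(=O)c1ccc(Cl)cc1`) : > 300000 nM (a limit)
compound 2 (`CCOc1ccc(F)cc1C(C)NC(=O)N(C)S(=O)(=O)c1ccc(Cl)cc1`) : 24500 nM
compound 3 (`CCOc1ccc(F)cc1C(C)NC(=O)NS(=O)(=O)c1ccccc1`) : > 300000 nM (a limit)

Compound 1 gives no number in this assay: its > 300000 nM is a limit. Compound 1 sits at the limit of > 300000 nM in this assay, at which 2 of the 3 values shown sit, and compound 3 sits at the same limit.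

Compound 4 (`CCOc1ccc(Br)cc1C(C)NC(=O)NS(=O)(=O)c1ccc(Cl)cc1`) differs from compound 1 by bromo in place of fluoro on an aromatic carbon, with bromo in place of fluoro on an aromatic carbon, para to an ethoxy group.

Two measured steps start from compound 1, and neither touches the fluoro. Methyl in place of hydrogen on an amide-type nitrogen gave an at least 12-fold lower number from compound 1 to compound 2 (1.08 log units; beyond the scatter), a large change at another place. Hydrogen in place of chloro on an aromatic carbon gave a step that the two limits leave unreadable from compound 1 to compound 3, so it provides no size. Within the data shown here, no measured step therefore sizes the exchange of fluoro for bromo, and the expectation rests on compound 1 and its limit of > 300000 nM. Compound 4 is expected to stay in the weak range of this assay, and another limit would fit that expectation. The expected step is an at least 1.2-fold lower number from compound 1 to compound 4 (0.07 log units; that floor lies within the scatter), with a wide margin. For compound 4 the estimate is 250000 nM, with an expected range from 50000 nM to 600000 nM.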

Compound 4, half-maximal effective concentration: 171000 nM
The estimate for compound 4 lay 1.5-fold (0.16 log units) above the measured number; measured number inside the range.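

In this assay, among these compounds, the aromatic carbon para to an ethoxy group now has a step of its own: the earlier steps from compound 1 changed the amide-type nitrogen and the chloro, and neither touched the fluoro. Bromo in place of fluoro gives an at least 1.7-fold lower number from compound 1 to compound 4 (0.24 log units; that floor lies within the scatter) and so yields a measured number on the core of compound 1, although that floor alone does not establish a change beyond the usual scatter. The value for compound 1 is a limit, and the step can therefore be given only as a floor, not as a full size: the limit of > 300000 nM in this assay, at which 2 of the 4 values shown sit.

The compounds shown leave open what a chloro, a methoxy, a nitrile or an amine would give at this position, since only fluoro and bromo can be compared there. Also open, from the compounds shown here alone, is whether a change like an at least 12-fold lower number from compound 1 to compound 2 (1.08 log units; beyond the scatter) would recur on compound 4 with methyl in place of hydrogen on the amide-type nitrogen.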